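Removing a Methyl from a Weak Inhibitor at the Assay Limit

The compounds below may be only part of what the source reports. "The series", "measured", "known", "first", "only" and "open" are said of these compounds alone.

Compound 1 `CCCc1nc(C)c2c(C)nnc(SC)n12` was tested in a functional assay for inhibition, with Homo sapiens as the target (a higher number here means a weaker inhibitor, a lower number a stronger inhibitor), where compound 1 gave only the limit of the assay, > 48000 nM, and no number. Two neighbours of compound 1 have been measured in this assay. Compound 2 `CCCc1nc(C)c2c(-c3ccccc3)nnc(SC)n12` also returned only the limit > 48000 nM. Compound 3 `CCCc1nc(C)c2c(C)nnc(O)n12` gave a number, 14000 nM. The step from compound 1 to compound 2, phenyl in place of methyl on an aromatic carbon, is a step that the two limits leave unreadable from compound 1 to compound 2. The step from compound 1 to compound 3, hydroxy in place of methylsulfanyl on an aromatic carbon, is an at least 3.4-fold lower number from compound 1 to compound 3 (0.53 log units; beyond the scatter). Both limits sit at the same point: the limit of > 48000 nM in this assay, at which 2 of the 3 values shown sit.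

Compound 4 `CCCc1ncc2c(C)nnc(SC)n12` differs from compound 1 as follows: hydrogen in place of methyl on an aromatic carbon. Neither measured step touches this methyl, so nothing shown reads directly on the change, and compound 1 itself offers only a limit to start from. The expected step for this small change is therefore none beyond the scatter, and compound 4 is expected to sit near the same limit, a step that the limit leaves unreadable from compound 1 to compound 4. For compound 4 the estimate in this assay is 60000 nM, with a range from 20000 nM to 150000 nM, and most likely the assay will again report only a limit.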

Compound 4, half-maximal inhibitory concentration: > 48000 nM
Compound 4: only a limit was reported (the forecaster's own chance of this, stated with the estimate: 80%); the middle value does not contradict the limit.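

In this assay compound 1 and compound 4 both returned only a limit and no number, so no step can be read between them: the limit of > 48000 nM in this assay, at which 3 of the 4 values shown sit. The compounds shown leave open whether hydrogen in place of methyl on an aromatic carbon changes inhibition at all, including on a compound that gives a number, such as compound 3.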